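Pyrazole series: chloro-to-methyl step on the pendant aryl ring

The compounds below may be only part of what the source reports. "The series", "measured", "known", "first", "only" and "open" are said of these compounds alone.

Three compounds have been run so far in a functional assay on the whole organism (strain albino) for inhibition, with Rattus norvegicus as the target, read by paw edema, with stated times of 30 min and 4 h, at a dose of 50 mg/kg by the oral route; on this read-out lower numbers stand for less inhibition and higher numbers for more inhibition at the one dose given (going by the name of the read-out). Compound 1 `O=C(O)CCC(=O)/C=C/c1cn(-c2ccccc2)nc1-c1ccc(Cl)cc1` gives 8.64% in this assay. Compound 2 `Cc1ccc(-c2nn(-c3ccccc3)cc2/C=C/C(=O)CCC(=O)O)cc1` differs from compound 1 only by methyl in place of chloro on an aromatic carbon. In this assay, among the compounds with values here, compound 2 gives 13%; the step of a number 4.4 percentage points higher from compound 1 to compound 2 (within the scatter) is the single measured instance of this change. Compound 3 `CC(=O)Nc1ccc(OC(=O)c2cn(-c3ccccc3)nc2-c2ccc(Cl)cc2)cc1` carries a different core; the difference between the core of compound 1 and the core of compound 3 is not broken down here. In this assay compound 3 gives 16.1%. All three numbers sit within the scatter of one another, so no ordering among compounds 1, 2 and 3 is claimed.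

Compound 4 `CC(=O)Nc1ccc(OC(=O)c2cn(-c3ccccc3)nc2-c2ccc(C)cc2)cc1` is the unmeasured member. It differs from compound 3 by methyl in place of chloro on an aromatic carbon, and the place of this change is the same, word for word, as the place of the change from compound 1 to compound 2, so it is taken as the same change carried onto the core of compound 3. Within the data shown here, the only precedent is a number 4.4 percentage points higher from compound 1 to compound 2 (within the scatter), a step that lies within the scatter, so for compound 4 a step of about a number 3.9 percentage points higher from compound 3 to compound 4 (within the scatter) is expected, again within the scatter, resting on that single pair. Compound 4 is therefore expected to give about 20% in this assay, with a range from 9% to 31% expected to hold most repeat measurements.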

Compound 4, a percentage reported as inhibition, in the whole organism at one dose (the size of the read-out at that dose, not a potency): 3.7%
Beside the measured number, compound 4's estimate is 16.3 percentage points above it; the measured number lies below the stated range.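

In this assay, the exchange of chloro for methyl does not behave as one fixed step across the two cores. On the core of compound 3 it gives a number 12.4 percentage points lower from compound 3 to compound 4 (beyond the scatter), and the two instances differ: the same change on two cores in this assay, a number 4.4 percentage points higher (within the scatter) from compound 1 to compound 2 and a number 12.4 percentage points lower (beyond the scatter) from compound 3 to compound 4, 16.8 percentage points apart, beyond the scatter of two such steps

This shows that, for these two pairs, the result of the change depends on the core that carries it, so a step read on one core cannot simply be transferred to the other. Within the data shown here, it does not show why the steps differ or give a rule for the series, since each core contributes a single pair, only the step on the core of compound 3 lies beyond the scatter, and all readings come from one dose.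

Still open, going by these compounds, is whether a third core carrying the same exchange would follow either step, and whether the step on the core of compound 3 extends to other groups in the same place, such as fluoro, methoxy or trifluoromethyl. Also open, on these data alone, is how the exchange from 4-chlorophenyl to 4-methylphenyl behaves if an amide replaces the ester link of compound 3.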